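This account rests on a few compounds, and the source may have more. Where it says the series, first, only, none or still open, it means among the compounds named here.

Compound 1 `O=C(CC(CC(=O)NC1Cc2ccccc2C1)c1ccccc1)NCCN1CCCCC1` and compound 2 `O=C(CC(CC(=O)NC1Cc2ccccc2C1)c1ccccc1)NCCN1CCCC1` share one core. In a functional assay on HeLa cells (Homo sapiens) for inhibition (on this read-out higher numbers stand for weaker inhibition and lower numbers for stronger inhibition), compound 1 gives only a limit of the assay, > 100000 nM. Compound 2 in this assay likewise gives only a limit, > 100000 nM. The change made between them is pyrrolidin-1-yl in place of piperidin-1-yl on a saturated chain carbon, two bonds along the chain from an amide-type nitrogen, and the step that the two limits leave unreadable from compound 1 to compound 2 is unreadable because of the limit of > 100000 nM in this assay, at which 2 of the 3 values shown sit. Compound 3 `CCN(C(=O)CC(CC(=O)NCCN1CCCCC1)c1ccc(Cl)cc1)C1Cc2ccccc2C1` has another core; the difference between the two cores is not broken down here. In this assay compound 3 gives 20400 nM. Compound 4 `CCN(C(=O)CC(CC(=O)NCCN1CCCC1)c1ccc(Cl)cc1)C1Cc2ccccc2C1` repeats the same kind of change on the core of compound 3: pyrrolidin-1-yl in place of piperidin-1-yl on a saturated chain carbon, two bonds along the chain from an amide-type nitrogen. The expected step is a 1.2-fold higher number from compound 3 to compound 4 (0.09 log units; within the scatter), resting on compound 3 at 20400 nM and on the unreadable step that the two limits leave unreadable from compound 1 to compound 2, which gives no measured size for the change. Compound 4 is expected to give about 25000 nM, between 8000 nM and 80000 nM.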

Compound 4, half-maximal inhibitory concentration: 36400 nM
Compound 4: middle estimate off by 1.5-fold (0.16 log units), on the low side, within the range that was stated.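

In this assay, pyrrolidin-1-yl in place of piperidin-1-yl on the core of compound 3 gives a 1.8-fold higher number from compound 3 to compound 4 (0.25 log units; within the scatter). On this core, the two compounds therefore stand within the scatter of each other, and this single pair gives no readable effect of the change. The matching step on the core of compound 1 cannot be read, and carrying the change from one core to another remains untested, because both values on that core are limits of the assay: the limit of > 100000 nM in this assay, at which 2 of the 4 values shown sit.

Open, as far as these compounds go, is how other amines in place of piperidin-1-yl, such as morpholin-4-yl or dimethylamino, would read on the core of compound 3. Also open, from the compounds shown here alone, is whether a longer chain in place of 2-(piperidin-1-yl)ethyl would give a step beyond the scatter.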